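Shifting the methyl around the pyrazole amide

A few compounds are considered here, and "the series" means these few. Any claim that something is new, unique, unknown or untested is made for them only; others in the source may bear on it.

In an assay on cells for positive allosteric modulation of Cystic fibrosis transmembrane conductance regulator variant F508del (Homo sapiens), with stated times of 10 min and 7 s, in the presence of a further agent that is not named here (a lower number here means that less compound is needed, a higher number that more compound is needed for the effect), compound 3 `Cc1cn[nH]c1C(=O)Nc1sc2c(c1C(N)=O)CC(C)(C)OC2(C)C` gives 2 nM, the second highest of three numbers. Compound 1 `CC1(C)Cc2c(sc(NC(=O)c3ccn[nH]3)c2C(N)=O)C(C)(C)O1` gives 3 nM in this assay, and compound 2 `CC(C)(C)CC(O)C(=O)Nc1sc2c(c1C(N)=O)CC(C)(C)OC2(C)C` gives 0.54 nM, the lowest; a 3.7-fold higher number from compound 2 to compound 3 (0.57 log units; beyond the scatter), while a 5.6-fold lower number from compound 1 to compound 2 (0.74 log units; beyond the scatter). Compound 4 `Cc1cc(C(=O)Nc2sc3c(c2C(N)=O)CC(C)(C)OC3(C)C)[nH]n1` keeps the same atoms as compound 3, joined differently: 3-methyl-1H-pyrazol-5-yl in place of 4-methyl-1H-pyrazol-5-yl on a carbonyl carbon. Among the measured compounds shown here, no measured step moves the methyl around this ring; the only step that touches it, a 1.5-fold lower number from compound 1 to compound 3 (0.18 log units; within the scatter), stayed within the scatter. No step beyond the scatter is therefore expected in this assay. Compound 4 is estimated to give 2 nM in this assay, within a range of 0.8 nM to 5 nM. That estimate means an expected step of no change at the digits printed from compound 3 to compound 4 (within the scatter).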

Compound 4, half-maximal effective concentration: 13 nM
Beside the measured number, compound 4's estimate is 6.5-fold (0.81 log units) below it; the measured number lies above the stated range.
By their numbers in this assay, from the lowest: compound 2; then compounds 3 and 1 (each within the scatter of the next); then compound 4.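

In this assay the place of the methyl on the pyrazole matters, with a 6.5-fold higher number from compound 3 to compound 4 (0.81 log units; beyond the scatter) for the same atoms joined differently. Adding a methyl to the unsubstituted pyrazole therefore has an outcome that depends on where it goes: a 1.5-fold lower number from compound 1 to compound 3 (0.18 log units; within the scatter) stays within the scatter, while a 4.3-fold higher number from compound 1 to compound 4 (0.64 log units; beyond the scatter) goes beyond it. The 3-methyl-1H-pyrazol-5-yl group also falls well short of the open-chain group, with a 24-fold higher number from compound 2 to compound 4 (1.38 log units; beyond the scatter) as the step. No evidence here accounts for the shift. Going by these compounds, whether an ethyl group or a chlorine in place of the methyl of 4-methyl-1H-pyrazol-5-yl would keep the number of compound 3 remains open.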